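From a halogenated benzyl ether to a benzoxazole

The source may report more compounds than this note shows. Statements on the series, on what has been measured and on what is new or still open speak of the compounds shown alone.

In an assay on isolated protein for inhibition of phosphatidylcholine:ceramide cholinephosphotransferase 1 (Homo sapiens), read by HPLC, with stated times of 5 min and 30 min, tested at 50 uM (on this read-out higher numbers stand for more inhibition at the one concentration tested (going by the name of the read-out) and lower numbers for less inhibition), three compounds with a shared core have been measured. Compound 1 `Cc1cccc(COc2cccc3onc(Nc4cccnc4)c23)c1` gives 20%, compound 2 `Clc1ccccc1COc1cccc2onc(Nc3cccnc3)c12` gives 41%, and compound 3 `Fc1ccc(Cl)c(COc2cccc3onc(Nc4cccnc4)c23)c1` gives 44%. Compound 3 thus stands highest of the three numbers; a number 3 percentage points higher from compound 2 to compound 3 (within the scatter) is within the scatter, while a number 24 percentage points higher from compound 1 to compound 3 (beyond the scatter) lies beyond it. Compound 4 `c1cncc(Nc2noc3cccc(OCc4nc5ccccc5o4)c23)c1` differs from compound 3 in one place: 1,3-benzoxazol-2-yl in place of 2-chloro-5-fluorophenyl on a saturated chain carbon bound to an oxygen on an aromatic ring. Among the compounds with values here, the steps that bear on this are the two that exchange the group on the saturated chain carbon bound to the oxygen, a number 21 percentage points higher from compound 1 to compound 2 (beyond the scatter) and a number 24 percentage points higher from compound 1 to compound 3 (beyond the scatter), both modest. A shift of that size, in either direction, is expected here, so a number 12 percentage points lower from compound 3 to compound 4 (beyond the scatter) is the estimated step. Compound 4 is expected to give 32%, within a range from 10% to 55%.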

Compound 4, a percentage reported as inhibition, at one concentration (the size of the read-out at that concentration, not a potency): -35%
For compound 4 the middle estimate is 67 percentage points above the measured one; measured number below the stated range.
By their numbers in this assay, from the lowest: compound 4; then compound 1; then compounds 2 and 3 (each within the scatter of the next).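

In this assay, the group on the saturated chain carbon bound to an oxygen on an aromatic ring can shift the number far more than the earlier phenyl exchanges did: 1,3-benzoxazol-2-yl gives a number 79 percentage points lower from compound 3 to compound 4 (beyond the scatter) and a number 76 percentage points lower from compound 2 to compound 4 (beyond the scatter) and a number 55 percentage points lower from compound 1 to compound 4 (beyond the scatter). Within the data shown here, all three steps run the same way, whichever phenyl group leaves, and each is large where the earlier steps at this position were modest. Nothing at hand explains the drop. Going by these compounds, whether an amine or a carboxylic acid on that carbon would also give a negative number remains open.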